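Amide variation on a weakly cytotoxic aminopyrazolopyridine scaffold

The source may hold more compounds than are shown below. What is called first, only, known or untested is meant among the compounds shown, and "the series" means these compounds.

Compound 1 `CNC(=O)Cn1nc(N)c2c(C(F)(F)F)cc(-c3ccccc3)nc21`: 11800 nM
Compound 2 `Nc1nn(CC(=O)NC2CC2)c2nc(-c3ccccc3)cc(C(F)(F)F)c12`: "not active" (no number reported)

Going by the values given here, in a functional assay on MCF7 cells (Homo sapiens) for cytotoxicity, read by MTT assay, with a stated time of 24 h (a lower number here means a stronger inhibitor, a higher number a weaker inhibitor), compound 1 gives 11800 nM, the only number in the set. Among the compounds with values here, compound 2 gives "not active" (no number reported), with no number reported, so it offers no step to compare against. Compound 3 `CN1CCN(C(=O)Cn2nc(N)c3c(C(F)(F)F)cc(-c4ccccc4)nc32)CC1` differs from compound 1 at the carbonyl carbon: 4-methylpiperazin-1-yl in place of methylamino on a carbonyl carbon. Within the data shown here, with no measured step of this kind available, the size of the expected change is uncertain; the expected step of a 1.4-fold higher number from compound 1 to compound 3 (0.13 log units; within the scatter) is no larger than the scatter, leaning toward weaker inhibition. Compound 3 is therefore estimated at 16000 nM, within 5000 nM to 50000 nM.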

Compound 3, half-maximal inhibitory concentration: 16600 nM
Estimate against measurement, compound 3: 1.0-fold (0.02 log units) below; measured number inside the range.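

In this assay the change from methylamino to 4-methylpiperazin-1-yl on the carbonyl carbon gives a 1.4-fold higher number from compound 1 to compound 3 (0.15 log units; within the scatter) and so lies within the scatter. This position therefore accepts the six-membered ring and the loss of the amide hydrogen without a readable change in the number. The step to compound 2 cannot be read, and no measurement bears on why the number holds. Still open, going by these compounds, is whether a carboxylic acid or a morpholine at this carbonyl carbon would move the number beyond the scatter.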